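Swapping a halogenated phenyl on an inactive analogue

A few compounds are considered here, and "the series" means these few. Any claim that something is new, unique, unknown or untested is made for them only; others in the source may bear on it.

Compound 1 `COc1ccccc1/C=c1\c(=O)[nH]/c(=C/c2ccccc2Cl)c(=O)n1C` and compound 3 `COc1ccccc1/C=c1/[nH]c(=O)/c(=C\c2nc[nH]c2C(C)(C)C)[nH]c1=O` share a core with compound 2 `C=CCn1c(=O)/c(=C\c2ccc(F)c(Br)c2)[nH]c(=O)/c1=C\c1ccccc1OC`. In a functional assay on NCI-H1975 cells (Homo sapiens) for cytotoxicity, read by CCK-8 assay, with a stated time of 72 h (on this read-out higher numbers stand for weaker inhibition and lower numbers for stronger inhibition), compound 1 gives 200 nM, and in this assay compound 3 gives 100 nM. In this assay compound 2 is recorded as "not active" (no number reported), so no number is available and it stands apart from compounds 1 and 3, which both have measured values. Compound 4 `C=CCn1c(=O)/c(=C\c2cccc(Cl)c2Cl)[nH]c(=O)/c1=C\c1ccccc1OC` differs from compound 2 by one change: 2,3-dichlorophenyl in place of 3-bromo-4-fluorophenyl on a double-bonded chain carbon bound to an aromatic carbon. For the measured compounds named here, no measured pair shows this kind of change, so the size of the step in this assay cannot be read from the data; an outcome near that of compound 2 seems most likely. Compound 4 is expected to give about 5000 nM, estimated between 500 nM and 50000 nM.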

Compound 4, half-maximal inhibitory concentration: 4500 nM
Beside the measured number, compound 4's estimate is 1.1-fold (0.05 log units) above it, and the stated range covers the measured number.
By their numbers in this assay, from the lowest: compounds 3 and 1 (each within the scatter of the next); then compound 4.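

Compound 2 has no number, so no step to compound 4 can be read, and no measurement shown explains the result. The compounds shown leave open how far swapping 3-bromo-4-fluorophenyl for 2,3-dichlorophenyl moves activity.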